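Lengthening the Basic Side Chain on a Diaryl Urea

The compounds below may be only part of what the source reports. "The series", "measured", "known", "first", "only" and "open" are said of these compounds alone.

Measured compounds:
compound 1, `CN(C)CCNc1nc(-c2ccc(NC(=O)Nc3ccc(Cl)cc3)cc2)nc2c(Cl)c(Cl)sc12`, 300 nM
compound 2, `CN(C)CCNc1nc(-c2ccc(NC(=O)Nc3ccccc3Cl)cc2)nc2c(Cl)c(Cl)sc12`, 440 nM
compound 3, `CN(C)CCNc1nc(-c2ccc(NC(=O)Nc3ccc(Cl)cc3Cl)cc2)nc2c(Cl)c(Cl)sc12`, 1520 nM

In a functional assay on NCI-H460 cells (Homo sapiens) for cytotoxicity, read by MTT assay, with a stated time of 72 h (a lower number here means a stronger inhibitor, a higher number a weaker inhibitor), compound 1 gives 300 nM, the lowest of the three numbers. Compound 2 sits close by: the change is a 1.5-fold higher number from compound 1 to compound 2 (0.17 log units; within the scatter), and the two values cannot be told apart. Compound 3 stands furthest off, with a 5.1-fold higher number from compound 1 to compound 3 (0.70 log units; beyond the scatter) and, from the other side, a 3.5-fold higher number from compound 2 to compound 3 (0.54 log units; beyond the scatter); both of these are modest steps that do lie beyond the scatter.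

Compound 4, `CCN(CC)CCCNc1nc(-c2ccc(NC(=O)Nc3ccc(Cl)cc3)cc2)nc2c(Cl)c(Cl)sc12`, differs from compound 1 in another part of the molecule: (diethylamino)methyl in place of dimethylamino on a saturated chain carbon, two bonds along the chain from a nitrogen on an aromatic ring. Every measured step concerns only the chloro pattern of the chlorophenyl on the amide-type nitrogen; none touches the amine-bearing chain. So no measured step bears on this change, and the data give no direction for it. The expectation therefore rests on compound 1 alone, and the step is expected to be no change at the digits printed from compound 1 to compound 4 (within the scatter), that is, nothing beyond the scatter, with a wider margin to reflect the lack of a precedent. Compound 4 is estimated at 300 nM in this assay, within a range of 110 nM to 900 nM.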

Compound 4, half-maximal inhibitory concentration: 270 nM
For compound 4 the middle estimate is 1.1-fold (0.05 log units) above the measured one; low and high end bracket the measured number.
By their numbers in this assay, from the lowest: compounds 4, 1 and 2 (each within the scatter of the next); then compound 3.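

In this assay, replacing the (2-(dimethylamino)ethyl)amino chain of compound 1 with the (3-(diethylamino)propyl)amino chain gives a 1.1-fold lower number from compound 1 to compound 4 (0.05 log units; within the scatter), so the two compounds cannot be told apart. Among the compounds shown here, this is the first measured change away from the chlorophenyl on the amide-type nitrogen, and it shows that, with the 4-chlorophenyl urea and the shared core held constant, 6 heavy atoms can stand in place of 3 at this position without a step beyond the scatter. No supporting measurement bears on this result, so the reading stops at the cell value itself.

Chain length and the groups on the terminal amine differ together in this one pair, so the separate contributions of 2-(diethylamino)ethyl and 3-(dimethylamino)propyl remain open, as does the outcome of ending the chain in a ring amine such as morpholine or piperidine. As far as these compounds go, it also remains open whether the same chain change would read the same way alongside the 2-chlorophenyl of compound 2 or the dichlorophenyl of compound 3.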